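The source may report more compounds than this note shows. Statements on the series, on what has been measured and on what is new or still open speak of the compounds shown alone.

Measured so far in a functional assay on I10 cells (Mus musculus) for inhibition, read by MTT assay, with a stated time of 72 h; on this read-out lower numbers stand for stronger inhibition and higher numbers for weaker inhibition:
compound 1 `C=CCc1ccc(OCc2ccccc2)c(-c2ccc(O)c(CC=C)c2)c1` gives 21800 nM
compound 2 `C=CCc1ccc(OCc2ccc(Cl)cc2Cl)c(-c2ccc(OCc3ccc(Cl)cc3Cl)c(CC=C)c2)c1` gives > 50000 nM, which is a limit of the assay, not a number
compound 3 `C=CCc1ccc(O)c(-c2ccc(OCc3ccc(Cl)cc3Cl)c(CC=C)c2)c1` gives 10400 nM

Compound 2 stands with a limit only; of the three values in this assay, one sits at that limit (the limit of > 50000 nM in this assay, at which 1 of the 3 values shown sits). Within the data shown here, compound 1 and compound 3 both give numbers, so compound 2 is the one member of the set for which no number is available.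

The unmeasured compound 4 `C=CCc1ccc(OCc2ccc(Cl)cc2Cl)c(-c2ccc(O)c(CC=C)c2)c1` differs from compound 2 in one place: hydrogen in place of 2,4-dichlorobenzyl on an oxygen on an aromatic ring.

Among the measured compounds shown here, one measured step bears on this change: an at least 4.8-fold lower number from compound 2 to compound 3 (0.68 log units; beyond the scatter), the same kind of change made in compound 3. Since that step gave a lower number beyond the scatter, a step of similar size and direction is expected here. A step of an at least 4.5-fold lower number from compound 2 to compound 4 (0.65 log units; beyond the scatter) is expected. Compound 4 is therefore estimated at 11000 nM in this assay, with a range from 4000 nM to 35000 nM.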

Compound 4, half-maximal inhibitory concentration: 21100 nM
Estimate against measurement, compound 4: 1.9-fold (0.28 log units) below; low and high end bracket the measured number.
By their numbers in this assay, from the lowest: compound 3; then compounds 4 and 1 (each within the scatter of the next). At a limit, above all of these: compound 2.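

In this assay, hydrogen in place of 2,4-dichlorobenzyl gives an at least 2.3-fold lower number from compound 2 to compound 4 (0.37 log units; beyond the scatter), so the lower number seen with this change now holds at both oxygens of compound 2 that carry this group. This step is a bound, as compound 2 has only a limit and not a number: the limit of > 50000 nM in this assay, at which 1 of the 4 values shown sits. With 2,4-dichlorophenyl in place of phenyl on the saturated chain carbon bound to an oxygen on an aromatic ring, the series shows a 1.0-fold lower number from compound 1 to compound 4 (0.01 log units; within the scatter), so the two chlorines do not separate these compounds in this assay.

Still open, on these data alone, is how the number would read with hydrogen on both oxygens of the shared core. Also open, as far as these compounds go, is what an amine or a carboxylic acid on a longer chain would do in place of the benzyl group on this oxygen.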